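A few compounds are considered here, and "the series" means these few. Any claim that something is new, unique, unknown or untested is made for them only; others in the source may bear on it.

Compound 1 `CC(=O)Oc1ccccc1C(=O)O[C@H]1CO[C@H]2[C@@H]1OC[C@H]2OC(=O)c1cccc(O)c1`, 0.0183 h; compound 2 `CC(=O)Oc1ccccc1C(=O)O[C@H]1CO[C@H]2[C@@H]1OC[C@H]2OC(=O)c1ccc(C)cc1`, 0.105 h.
Compound 3 `CC(=O)Oc1ccccc1C(=O)O[C@H]1CO[C@H]2[C@@H]1OC[C@H]2OC(=O)c1ccc(-c2ccccc2)cc1` reaches only a limit of the assay, > 0.333 h.

In an ADME assay on a cell-free system (plasma, Homo sapiens) for metabolic stability, with Plasma (Rattus norvegicus) as the target, read by HPLC, at pH 7.4 (a higher number here means that the compound lasts longer, a lower number that the compound disappears faster), compound 1 gives 0.0183 h, the lowest of the two numbers shown, and compound 2 gives 0.105 h. The value of compound 3 is a limit of the assay, (the limit of > 0.333 h in this assay, at which 1 of the 3 values shown sits), not a number. Compound 4 `CC(=O)Oc1ccccc1C(=O)O[C@H]1CO[C@H]2[C@@H]1OC[C@H]2OC(=O)c1ccccc1CO[N+](=O)[O-]` differs from compound 1 in one place: 2-((nitrooxy)methyl)phenyl in place of 3-hydroxyphenyl on a carbonyl carbon. Among the compounds with values here, two measured steps bear on this change, both of them leaving 3-hydroxyphenyl: a 5.7-fold higher number from compound 1 to compound 2 (0.76 log units; beyond the scatter) and an at least 18-fold higher number from compound 1 to compound 3 (1.25 log units; beyond the scatter). Both run toward a higher number, one modest and one large. Compound 4 is therefore expected to last longer than compound 1, and the expected step is a 4.4-fold higher number from compound 1 to compound 4 (0.64 log units; beyond the scatter). For compound 4 the estimated value is 0.08 h, with a range from 0.03 h to 0.25 h.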

Compound 4, half-life: 0.045 h
Estimate against measurement, compound 4: 1.8-fold (0.25 log units) above; measured number inside the range.
By their numbers in this assay, from the lowest: compound 1; then compound 4; then compound 2. At a limit, above all of these: compound 3.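

Leaving 3-hydroxyphenyl raises the number with a third group as well, a 2.5-fold higher number from compound 1 to compound 4 (0.39 log units; beyond the scatter), so the rise at this carbonyl carbon is not confined to the two earlier groups. Its size depends on the entering group, however: 2-((nitrooxy)methyl)phenyl gives a 2.3-fold lower number from compound 2 to compound 4 (0.37 log units; beyond the scatter) against 4-methylphenyl and an at least 7.4-fold lower number from compound 3 to compound 4 (0.86 log units; beyond the scatter) against 4-phenylphenyl. The value of compound 3 is a limit, not a number: the limit of > 0.333 h in this assay, at which 1 of the 4 values shown sits.

The compounds shown leave open whether an amine or a carboxylic acid on this carbonyl carbon's phenyl ring would follow the same rise.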